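Flavone series: aminoalkyl side chains and antiproliferative read-out

The compounds below may be only part of what the source reports. "The series", "measured", "known", "first", "only" and "open" are said of these compounds alone.

Measured so far:
compound 1, `COc1cc(OC)c2c(=O)cc(-c3ccc(OC4CCNCC4)cc3)oc2c1`: "not active" (no number reported)
compound 2, `COc1cc(OC)c2c(=O)cc(-c3ccc(OCCCN)cc3)oc2c1`: 22%
compound 3, `COc1cc(OC)c2c(=O)cc(-c3ccc(OCC(O)CN4CCCC4)cc3)oc2c1`: 21%

In a functional assay (Homo sapiens) for antiproliferative activity, read by resazurin assay, with a stated time of 48 h, tested at 5 uM (on this read-out higher numbers stand for a stronger effect at the one concentration tested and lower numbers for a weaker effect), compound 3 gives 21%, the lowest of the two numbers reported, with compound 2 nearest at 22%. Compound 1 is reported only as "not active" (no number reported), without a number. Among the measured compounds shown here, the one measured step, a number 1 percentage points lower from compound 2 to compound 3 (within the scatter), shows that the change on the chain carbon bound to the ring oxygen left this assay essentially unmoved.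

Compound 4, `COc1cc(OC)c2c(=O)cc(-c3ccc(NCCN4CCCC4)cc3)oc2c1`, carries (2-(pyrrolidin-1-yl)ethyl)amino in place of 2-hydroxy-3-(pyrrolidin-1-yl)propoxy on an aromatic carbon. For the measured compounds named here, no measured step touches the link to the aromatic carbon itself, so the only guide is the flat step from compound 2 to compound 3. The expected step of a number 1 percentage points lower from compound 3 to compound 4 (within the scatter) is therefore small, without a clear direction. Compound 4 is estimated at 20%, expected between 5% and 38%.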

Compound 4, a percentage reported as inhibition, at one concentration (the size of the read-out at that concentration, not a potency): 21%
Compound 4: middle estimate off by 1 percentage points, on the low side; low and high end bracket the measured number.
By their numbers in this assay, from the lowest: compounds 3, 4 and 2 (each within the scatter of the next).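

In this assay, (2-(pyrrolidin-1-yl)ethyl)amino in place of 2-hydroxy-3-(pyrrolidin-1-yl)propoxy gives no change at the digits printed from compound 3 to compound 4 (within the scatter), and the same group in place of 3-aminopropoxy gives a number 1 percentage points lower from compound 2 to compound 4 (within the scatter). The link to the aromatic carbon, untouched by the earlier step, can thus be an amino nitrogen or an ether oxygen without the number leaving the scatter. Nothing on hand accounts for this flat result. Still open, from the compounds shown here alone, is whether a carboxylic acid or a longer chain on this aromatic carbon would move the number in this assay.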